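From Nitro to Fluoro in Compound 3

The source may report more compounds than this note shows. Statements on the series, on what has been measured and on what is new or still open speak of the compounds shown alone.

Compound 1 `O=C1/C(=C/c2ccncc2)CN(S(=O)(=O)c2ccc(F)cc2)C/C1=C\c1ccccc1F`: 9100 nM
Compound 2 `Cc1ccc(S(=O)(=O)N2C/C(=C\c3ccncc3)C(=O)/C(=C/c3ccccc3C(F)(F)F)C2)cc1`: 5090 nM
Compound 3 `O=C1/C(=C/c2ccncc2)CN(S(=O)(=O)c2ccc([N+](=O)[O-])cc2)C/C1=C\c1ccccc1C(F)(F)F`: 9730 nM

In a functional assay on QGY-7703 cells (Homo sapiens) for cytotoxicity, read by MTT assay, with a stated time of 24 h (on this read-out higher numbers stand for weaker inhibition and lower numbers for stronger inhibition), compound 3 gives 9730 nM, a value within the usual scatter of both other compounds, so the three cannot be ranked. The next molecule, compound 4 `O=C1/C(=C/c2ccncc2)CN(S(=O)(=O)c2ccc(F)cc2)C/C1=C\c1ccccc1C(F)(F)F`, keeps everything except one group, with fluoro in place of nitro on an aromatic carbon.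

One measured step swaps a group at this same place, nitro in place of methyl, and it is a 1.9-fold higher number from compound 2 to compound 3 (0.28 log units; within the scatter). That swap did not move the number beyond the scatter, although it is a different exchange from the one here. The (4-fluorophenyl)sulfonyl group of compound 4 also appears in compound 1, at 9100 nM, although the other end of that molecule differs.

The expected change is therefore no larger than the scatter, in neither direction, and the estimated step is a 1.2-fold lower number from compound 3 to compound 4 (0.09 log units; within the scatter). For compound 4 the estimated value is 8000 nM, with an expected range from 3500 nM to 16000 nM.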

Compound 4, half-maximal inhibitory concentration: 7700 nM
The estimate for compound 4 lay 1.0-fold (0.02 log units) above the measured number; measured number inside the range.
By their numbers in this assay, from the lowest: compounds 2, 4, 1 and 3 (each within the scatter of the next).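

In this assay, fluoro in place of nitro gives a 1.3-fold lower number from compound 3 to compound 4 (0.10 log units; within the scatter), so a group of one heavy atom can replace one of three heavy atoms at this aromatic carbon without moving the number beyond the scatter. Fluoro in place of methyl at the same carbon gives a 1.5-fold higher number from compound 2 to compound 4 (0.18 log units; within the scatter), which means that nitro, methyl and fluoro cannot be ranked here. A change in another place, trifluoromethyl in place of fluoro, gives a 1.2-fold lower number from compound 1 to compound 4 (0.07 log units; within the scatter), so that exchange also leaves the number within the scatter. No measurement available here explains why these numbers stay so close. As far as these compounds go, whether an amine or a carboxylic acid on this aromatic carbon would shift the number beyond the scatter remains open.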